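From 3-Nitrophenoxy to 4-Bromophenoxy: An Expected Step

The source may hold more compounds than are shown below. What is called first, only, known or untested is meant among the compounds shown, and "the series" means these compounds.

compound 1 `COc1cc2c(cc1CC=C(C)C)C(=O)C[C@@H](c1ccc(Oc3cccc([N+](=O)[O-])c3)cc1)O2` — 21%
compound 2 `COc1ccc([C@@H]2C/C(=N/OCc3cn(-c4cc(OC)c(OC)c(OC)c4)nn3)c3cc(CC=C(C)C)c(OC)cc3O2)cc1` — 36%

Of the compounds shown here, two have been measured in a functional assay on PC-3 cells (Homo sapiens) for inhibition, read by sulforhodamine B assay, with a stated time of 48 h, tested at 50 uM; on this read-out higher numbers stand for more inhibition of growth at the one concentration tested and lower numbers for less inhibition of growth. Compound 1 gives 21%, the lower of the two numbers, while compound 2 gives 36%, a gap beyond the usual scatter. Compound 3 `COc1cc2c(cc1CC=C(C)C)C(=O)C[C@@H](c1ccc(Oc3ccc(Br)cc3)cc1)O2` has not yet been measured. It differs from compound 1 by 4-bromophenyl in place of 3-nitrophenyl on an oxygen on an aromatic ring. Within the data shown here, no measured pair shows this change, so its effect is unknown; the step expected a number 3 percentage points higher from compound 1 to compound 3 (within the scatter) is small, within the scatter, and in no particular direction. Compound 3 is therefore expected to give 24%, with a range from 8% to 42%.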

Compound 3, percent growth inhibition at one concentration: 55%
Estimate against measurement, compound 3: 31 percentage points below, outside the stated range (above it).
By their numbers in this assay, from the lowest: compound 1; then compound 2; then compound 3.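

Within this assay, the aryl group on this oxygen proves to be no neutral place: 4-bromophenyl in place of 3-nitrophenyl gives a number 34 percentage points higher from compound 1 to compound 3 (beyond the scatter) on an otherwise unchanged core. The earlier compounds shown here could not show this, since they formed no pair differing in one place. No measurement shown accounts for the size of this step. The change alters both the group on the ring and its place there, and the compounds shown do not separate the two. Going by these compounds, whether a chlorine or an amine in place of the bromine would keep the gain remains open.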